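The source may hold more compounds than are shown below. What is called first, only, known or untested is meant among the compounds shown, and "the series" means these compounds.

Compound 2 `O=C(Nc1ccc(N2CCN(c3ccc(OC[C@@H]4CO[C@@](Cn5cncn5)(c5ccc(Cl)cc5Cl)O4)cc3)CC2)cc1)c1cccc(F)c1` and compound 1 `O=C(CC1CCOCC1)Nc1ccc(N2CCN(c3ccc(OC[C@@H]4CO[C@@](Cn5cncn5)(c5ccc(Cl)cc5Cl)O4)cc3)CC2)cc1` share a common core and differ only in the group attached to the carbonyl carbon. In a functional assay on HepG2 cells (Homo sapiens) for inhibition, read by MTT assay, with a stated time of 48 h (a higher number here means a weaker inhibitor, a lower number a stronger inhibitor), compound 1 gives 21100 nM, and in this assay compound 2 gives 10800 nM. The step between them, a 2.0-fold lower number from compound 1 to compound 2 (0.29 log units; within the scatter), stays within the scatter, so compound 2 stands among two numbers with nothing separating it from compound 1 beyond the usual spread of repeated measurements. Compound 3 `O=C(Nc1ccc(N2CCN(c3ccc(OC[C@@H]4CO[C@@](Cn5cncn5)(c5ccc(Cl)cc5Cl)O4)cc3)CC2)cc1)c1ccc(F)c(F)c1` differs from compound 2 by fluoro in place of hydrogen on an aromatic carbon. Within the data shown here, no measured step of this kind exists among the two compounds at hand; the single measured step, a 2.0-fold lower number from compound 1 to compound 2 (0.29 log units; within the scatter), concerns a different part of the molecule and was itself within the scatter. Compound 3 is therefore expected to show no step beyond the scatter in this assay, a 1.1-fold lower number from compound 2 to compound 3 (0.06 log units; within the scatter). Compound 3 is estimated at 9500 nM, with a range from 4000 nM to 25000 nM.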

Compound 3, half-maximal inhibitory concentration: 19900 nM
The estimate for compound 3 lay 2.1-fold (0.32 log units) below the measured number, and the stated range covers the measured number.
By their numbers in this assay, from the lowest: compounds 2, 3 and 1 (each within the scatter of the next).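

In this assay, among these compounds, fluoro on this aromatic carbon, ortho to a fluoro group, turns 3-fluorophenyl into 3,4-difluorophenyl and gives a 1.8-fold higher number from compound 2 to compound 3 (0.27 log units; within the scatter) so the first change at this position stays within the usual spread of repeated measurements. Across the carbonyl carbon, 3,4-difluorophenyl in place of (oxan-4-yl)methyl gives a 1.1-fold lower number from compound 1 to compound 3 (0.03 log units; within the scatter) so this second comparison of those two sites also separates nothing, and all three compounds remain within the scatter of one another. No supporting information bears on these numbers.

As far as these compounds go, whether an amine, a carboxylic acid or a methoxy group at this aromatic carbon would give a step beyond the scatter stays open. The compounds shown also leave open whether a longer chain on the carbonyl carbon would do so.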